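Chloroalkyl urea to chloroalkyl amide in the antiproliferative series

The compounds below may be only part of what the source reports. "The series", "measured", "known", "first", "only" and "open" are said of these compounds alone.

Measured compounds, read in a functional assay on M21 cells (Homo sapiens) for antiproliferative activity, with a stated time of 48 h; a higher number here means a weaker inhibitor, a lower number a stronger inhibitor:
compound 1, `CCCCC(O)c1cccc(NC(=O)NCCCCl)c1`, gives 35000 nM.
compound 2, `CCCCC(O)c1cccc(NC(=O)NC(=O)CC)c1`, gives only a limit of the assay, > 100000 nM.

Compound 2 therefore stands at the limit, with no number of its own; of the two values shown, it is the one that sits at the limit of > 100000 nM in this assay, at which 1 of the 2 values shown sits. Among the measured compounds shown here, the only measured step is an at least 2.8-fold higher number from compound 1 to compound 2 (0.45 log units; beyond the scatter), and it runs away from the chloroalkyl chain toward the acyl group on the amide-type nitrogen.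

Compound 3, `CCCCC(O)c1cccc(NC(=O)CCCl)c1`, has not yet been measured. Its change from compound 2 is 2-chloroethyl in place of propanoylamino on a carbonyl carbon, which puts a chloroalkyl chain back onto the carbonyl carbon whose other neighbour is the amide-type nitrogen. The step from compound 1 to compound 2 bears on this, because an at least 2.8-fold higher number from compound 1 to compound 2 (0.45 log units; beyond the scatter) shows the loss on exchanging a chloroalkyl for an acyl group; reversing the sense of that exchange suggests a return toward the number of compound 1. In this assay compound 3 is accordingly expected to give 40000 nM, within 12000 nM to 150000 nM, a step estimated as an at least 2.5-fold lower number from compound 2 to compound 3 (0.39 log units; beyond the scatter).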

Compound 3, half-maximal inhibitory concentration: > 100000 nM
Compound 3: a limit, no number; the forecaster's own chance of this, stated with the estimate: 30%; middle value at least 2.5-fold (0.39 log units) from the limit.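

In this assay, 2-chloroethyl in place of (3-chloropropyl)amino on the carbonyl carbon gives an at least 2.8-fold higher number from compound 1 to compound 3 (0.45 log units; beyond the scatter), so a chloroalkyl chain on this carbonyl carbon is not enough on its own to keep a readable number. Compound 1, with its (3-chloropropyl)amino group, is the only one of the three to give a number, 35000 nM, and the amide-type nitrogen in that group is the feature that compound 3 lacks, although the change also alters the chain. Compound 2 and compound 3 both stand at a limit, and the step between them cannot be read: the limit of > 100000 nM in this assay, at which 2 of the 3 values shown sit.

The compounds shown leave open whether the nitrogen or the length of the chain carries the difference, which a 3-chloropropyl or 4-chlorobutyl chain on the same carbonyl carbon of the amide would help to separate. They also leave open whether the chlorine counts at all, which a plain propyl chain in place of 3-chloropropyl on the urea nitrogen of compound 1 would address.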